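Extending the chain on the sulfonamide aryl group

The source may hold more compounds than are shown below. What is called first, only, known or untested is meant among the compounds shown, and "the series" means these compounds.

Measured compounds:
Compound 1, `CCc1ccccc1NS(=O)(=O)c1ccc(N2CCNC2=O)cc1`: 350 nM
Compound 2, `CCc1ccc(NS(=O)(=O)c2ccc(N3CCNC3=O)cc2)cc1`: 810 nM

Both compounds were tested in a functional assay on MCF7 cells (Homo sapiens) for antiproliferative activity, read by sulforhodamine B assay, with a stated time of 48 h; on this read-out lower numbers stand for stronger inhibition and higher numbers for weaker inhibition. Compound 1, carrying a 2-ethylphenyl on the sulfonamide nitrogen, gives 350 nM, whereas compound 2, with a 4-ethylphenyl in the same place, gives 810 nM. Among the measured compounds shown here, the only step available is a 2.3-fold higher number from compound 1 to compound 2 (0.36 log units; beyond the scatter), so compound 2 stands at the higher of the two numbers, with compound 1 the nearer and only neighbour.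

Compound 3, `CCCCCc1ccc(NS(=O)(=O)c2ccc(N3CCNC3=O)cc2)cc1`, has not yet been measured. It differs from compound 2 by propyl in place of hydrogen on a saturated chain carbon, two bonds along the chain from an aromatic carbon. For the measured compounds named here, this is a different kind of change from the one between compound 1 and compound 2, which moved the ethyl group rather than lengthening it, so no measured step speaks directly to what a longer chain does here. Going by the values given here, the one step that exists was modest in size. Compound 3 is therefore expected to remain within the same broad range as compound 2, with a 1.2-fold higher number from compound 2 to compound 3 (0.09 log units; within the scatter) as the estimated step. Compound 3 is expected to give about 1000 nM, with a plausible span from 300 nM to 3500 nM.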

Compound 3, half-maximal inhibitory concentration: > 1000 nM
Compound 3 was reported as a limit (the forecaster's own chance of this, stated with the estimate: 5%); the middle value sits exactly at the limit.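

In this assay compound 3 is reported as > 1000 nM, which is a limit of the assay and not a number. On these data alone, the step is therefore only a floor, an at least 1.2-fold higher number from compound 2 to compound 3 (0.09 log units; that floor lies within the scatter), so going from ethyl to pentyl on this chain shows no stronger inhibition, while the size of any loss stays unknown. This is the first reading on chain length at this place, since the earlier pair only moved the ethyl group, and it marks where the read-out stops giving a number: the limit of > 1000 nM in this assay, at which 1 of the 3 values shown sits.

The compounds shown leave open how far beyond that limit compound 3 lies, and so whether lengthening the chain costs little or much. They also leave open how a propyl or butyl chain would read here, whether an amine or a carboxylic acid at the end of the chain would change the outcome, and whether a pentyl group would behave differently in the place the ethyl group holds in compound 1.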